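Removing a Methyl from a Phenolic Oxygen: What to Expect

The source may report more compounds than this note shows. Statements on the series, on what has been measured and on what is new or still open speak of the compounds shown alone.

Three hydrazone compounds built on closely related cores have been measured in a physicochemical assay, read by spectrophotometry, with a stated time of 6 min; on this read-out lower numbers stand for stronger inhibition and higher numbers for weaker inhibition. Compound 1 `O=C(CCc1nc2ccccc2c(=O)[nH]1)N/N=C/c1ccc(O)c(O)c1` gives 40000000 nM. Compound 2 `COc1ccc(/C=N/NC(=O)CCCc2nc3ccccc3c(=O)[nH]2)cc1` gives 180000000 nM, and compound 3 `COc1cc(/C=N/NC(=O)CCc2nc3ccccc3c(=O)[nH]2)ccc1O` gives 95000000 nM. The numbers for compound 2 and compound 3 lie within the usual scatter of each other, while compound 1 sits clearly lower than compound 2.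

Compound 3 and compound 1 differ in just one place: hydrogen in place of methyl on an oxygen on an aromatic ring. That change produced a 2.4-fold lower number from compound 3 to compound 1 (0.38 log units; beyond the scatter), a modest but real step.

Compound 4 `O=C(CCCc1nc2ccccc2c(=O)[nH]1)N/N=C/c1ccc(O)cc1` has not yet been measured. It arises from compound 2 by the same change: hydrogen in place of methyl on an oxygen on an aromatic ring. The difference between the core of compound 2 and the core of compound 3 is not broken down here, so the two pairs share the change but not the core.

Among the compounds with values here, the expectation for compound 4 rests on the single earlier example, a 2.4-fold lower number from compound 3 to compound 1 (0.38 log units; beyond the scatter). A step of similar size is expected: a 2.3-fold lower number from compound 2 to compound 4 (0.35 log units; beyond the scatter). On that basis compound 4 is estimated at 80000000 nM, with a likely range from 30000000 nM to 200000000 nM.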

Compound 4, half-maximal inhibitory concentration: 170000000 nM
Beside the measured number, compound 4's estimate is 2.1-fold (0.33 log units) below it; the measured number falls inside the stated range.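

In this assay, the same change, methoxy to hydroxy, gave a 1.1-fold lower number from compound 2 to compound 4 (0.02 log units; within the scatter) on this core, so here the step cannot be told apart from the ordinary spread of repeat measurements, whereas the earlier pair gave a 2.4-fold lower number from compound 3 to compound 1 (0.38 log units; beyond the scatter) and that step was beyond the scatter. Within the data shown here, this shows that a step seen on one core did not reappear at a readable size on the other, but with only two pairs it does not show that the core decides the outcome, nor how the change would behave on any further core. Nothing available explains why the two pairs read differently.

The compounds shown leave open whether the step seen between compound 3 and compound 1 or the flat result seen between compound 2 and compound 4 is the more usual one in this series. They also leave open how the number would read with an amine or a carboxylic acid in place of the hydroxy group of compound 4.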